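A longer hydroxycarbamoyl chain on compound 2

The compounds below may be only part of what the source reports. "The series", "measured", "known", "first", "only" and "open" are said of these compounds alone.

Measured in a functional assay on HCT-116 cells (Homo sapiens) for antiproliferative activity, read by CCK-8 assay, with a stated time of 48 h; a higher number here means a weaker inhibitor, a lower number a stronger inhibitor:
Compound 1 `O=C(CCCCCCOc1ccc(-c2nnc(-c3ccccc3)s2)cc1)NO`: 20000 nM
Compound 2 `O=C(CCCCOc1cccc(-c2nnc(-c3ccccc3)s2)c1)NO`: 2000 nM

Compound 2 holds the lower of the two numbers in this assay, and the gap to compound 1 lies beyond the usual scatter. Compound 3 `O=C(CCCCCOc1cccc(-c2nnc(-c3ccccc3)s2)c1)NO` has not yet been measured. It differs from compound 2 as follows: (hydroxycarbamoyl)methyl in place of hydroxycarbamoyl on a saturated chain carbon, four bonds along the chain from an oxygen on an aromatic ring. That places (hydroxycarbamoyl)methyl in place of hydroxycarbamoyl on a saturated chain carbon, four bonds along the chain from an oxygen on an aromatic ring. Among the measured compounds shown here, no measured pair isolates this change, so no step beyond the scatter is expected. The estimated change is a 1.1-fold lower number from compound 2 to compound 3 (0.05 log units; within the scatter). The expected value for compound 3 is 1800 nM, within an estimated range of 500 nM to 7000 nM.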

Compound 3, half-maximal inhibitory concentration: 470 nM
Beside the measured number, compound 3's estimate is 3.8-fold (0.58 log units) above it; the whole stated range lies above it.
By their numbers in this assay, from the lowest: compound 3; then compound 2; then compound 1.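

In this assay, (hydroxycarbamoyl)methyl in place of hydroxycarbamoyl on a saturated chain carbon, four bonds along the chain from an oxygen on an aromatic ring, brings a 4.3-fold lower number from compound 2 to compound 3 (0.63 log units; beyond the scatter) and so goes beyond the usual scatter. This is the first pair shown that differs in this one place, and it shows that the chain length at this position alone can move the number. No measured evidence accounts for this step. Still open, going by these compounds, is whether a longer chain, such as 2-(hydroxycarbamoyl)ethyl at this carbon, lowers the number further, and whether a carboxylic acid could stand in for the hydroxycarbamoyl group.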